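This account rests on a few compounds, and the source may have more. Where it says the series, first, only, none or still open, it means among the compounds named here.

Compound 1 `Cc1ccc(NC(=O)c2cc(Oc3ccc(S(C)(=O)=O)cc3)cc(OC(C)C)c2)nc1`, compound 2 `CC(C)Oc1cc(Oc2ccc(S(C)(=O)=O)cc2)cc(-c2cccc(=O)[nH]2)c1`, compound 3 `CC(C)Oc1cc(Oc2ccc(S(C)(=O)=O)cc2)cc(-c2ccnc(=O)[nH]2)c1` and compound 4 `CC(C)Oc1cc(Oc2ccc(S(C)(=O)=O)cc2)cc(-c2nccc(=O)[nH]2)c1` share the same core and differ only in the group attached to one aromatic carbon of it. In an ADME assay on MDCK-II cells (Canis lupus familiaris) for permeability (on this read-out lower numbers stand for lower permeability and higher numbers for higher permeability), compound 1 gives 4.4 10^-6 cm/s, and compound 2 gives 18 10^-6 cm/s. Going by the values given here, the one step within the measured set, a 4.1-fold higher number from compound 1 to compound 2 (0.61 log units; beyond the scatter), exchanges the group on that carbon and does not touch the part that changes here. In this assay compound 3 gives "not determined" (no result reported), so the path to compound 4 cannot be anchored on its direct parent.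

The change from compound 3 to compound 4 is a group of 7 heavy atoms (4 carbon, 2 nitrogen, 1 oxygen; one six-membered aromatic ring with 2 hetero atoms) in place of a group of 7 heavy atoms (4 carbon, 2 nitrogen, 1 oxygen; one six-membered aromatic ring with 2 hetero atoms), on an aromatic carbon: the same atoms, arranged differently inside the ring. Nothing measured speaks to this rearrangement, and the closest measured relative is compound 2, whose ring carries one hetero atom fewer. Compound 4 is therefore expected to fall near compound 2 or somewhat lower, with wide uncertainty; the estimate for compound 4 is 8 10^-6 cm/s, spanning 2.5 10^-6 cm/s to 25 10^-6 cm/s.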

Compound 4, apparent permeability: 24 10^-6 cm/s
The estimate for compound 4 lay 3.0-fold (0.48 log units) below the measured number; the range from low to high includes it.
By their numbers in this assay, from the lowest: compound 1; then compounds 2 and 4 (each within the scatter of the next).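

In this assay, exchanging the ring with 1 hetero atom for one with 2 hetero atoms on this aromatic carbon gives a 1.3-fold higher number from compound 2 to compound 4 (0.12 log units; within the scatter), so the extra hetero atom in compound 4 leaves the two read-outs indistinguishable. The higher number seen earlier relative to the larger group of compound 1 therefore also holds for this second six-membered ring, at a 5.5-fold higher number from compound 1 to compound 4 (0.74 log units; beyond the scatter). No available evidence gives a reason for either step.

On these data alone, compound 3 has no result, so the steps involving it cannot be read, and the effect of rearranging the same atoms inside the ring remains unknown. The compounds shown also leave open how a plain pyridine ring without the carbonyl, a carboxylic acid or an amine would read on this carbon.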